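Dimethylamino in place of chloro: an estimate for compound 3

The source may report more compounds than this note shows. Statements on the series, on what has been measured and on what is new or still open speak of the compounds shown alone.

Of the compounds shown here, two have been measured in a functional assay on cells (Leukemia cell, Homo sapiens) for cytotoxicity, read by sulforhodamine B assay, with a stated time of 48 h; on this read-out lower numbers stand for stronger inhibition of growth and higher numbers for weaker inhibition of growth. Compound 1 `O=C1N=C(N2N=C(c3ccccc3)CC2c2ccccc2O)S/C1=C1/C(=O)Nc2ccccc21` gives 3190 nM, and compound 2 `O=C1N=C(N2N=C(c3ccccc3)CC2c2ccc(Cl)cc2)S/C1=C1/C(=O)Nc2ccccc21` gives 370 nM, the lowest of the two numbers. Going by the values given here, the one measured step, an 8.6-fold lower number from compound 1 to compound 2 (0.94 log units; beyond the scatter), concerns a change on the saturated ring carbon, where 4-chlorophenyl replaced 2-hydroxyphenyl.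

Compound 3 `CN(C)c1ccc(C2CC(c3ccccc3)=NN2C2=NC(=O)/C(=C3\C(=O)Nc4ccccc43)S2)cc1` differs from compound 2 by dimethylamino in place of chloro on an aromatic carbon. The measured step from compound 1 to compound 2 altered the group on the same saturated ring carbon, so it bears on this change only loosely: it shows the assay answers to that position, but it says nothing about dimethylamino itself. Among the compounds with values here, no measured pair isolates dimethylamino against chloro. The step of a 1.9-fold higher number from compound 2 to compound 3 (0.28 log units; within the scatter) is therefore expected to be small, with the direction uncertain. Compound 3 is estimated at 700 nM, within a range of 150 nM to 3000 nM.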

Compound 3, concentration for 50% growth inhibition: 33900 nM
Beside the measured number, compound 3's estimate is 48-fold (1.69 log units) below it; the whole stated range lies below it.
By their numbers in this assay, from the lowest: compound 2; then compound 1; then compound 3.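

In this assay, dimethylamino in place of chloro on an aromatic carbon, para to a large group, gives a 92-fold higher number from compound 2 to compound 3 (1.96 log units; beyond the scatter) and so shows that this position, untested by the earlier pair, strongly affects the read-out. Changing 2-hydroxyphenyl on the saturated ring carbon now gives opposite outcomes: 4-chlorophenyl lowers the number, whereas 4-(dimethylamino)phenyl gives an 11-fold higher number from compound 1 to compound 3 (1.03 log units; beyond the scatter) in the same assay. The data shown offer no explanation for the size of either step.

Whether the high number is particular to dimethylamino remains open, as the compounds shown do not say how a methoxy group, a primary amine or a fluorine atom would read at this place. Nor do they show whether a smaller amine, such as methylamino, would fall nearer to chloro or to dimethylamino.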